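What one lost hydroxy may do to compound 2

A few compounds are considered here, and "the series" means these few. Any claim that something is new, unique, unknown or untested is made for them only; others in the source may bear on it.

Compound 1 `COc1ccc(-c2nn(-c3ccccc3)cc2/C=C2\SC(=O)N(Cc3ccccc3)C2=O)cc1`: 127 ug/mL
Compound 2 `O=C(c1cc(O)c(O)c(O)c1)c1cc(O)c(Br)cc1O`: 14.4 ug/mL
Compound 3 `Oc1cc(Cc2ccccc2)c(O)cc1Br`: 13.3 ug/mL

In a functional assay (on this read-out higher numbers stand for weaker inhibition and lower numbers for stronger inhibition), compound 2 gives 14.4 ug/mL and compound 3 gives 13.3 ug/mL and these two lie within the usual scatter of each other. Going by the values given here, compound 1 gives 127 ug/mL and that number is higher than the one for compound 2 by more than the scatter.

The next compound to be tested is compound 4 `O=C(c1ccc(O)c(O)c1)c1cc(O)c(Br)cc1O` and it differs from compound 2 in one place (hydrogen in place of hydroxy on an aromatic carbon): hydrogen in place of hydroxy on an aromatic carbon. Among the compounds with values here, no two measured compounds differ in a single place, so the data hold no direct precedent for this change. Within the data shown here, the only hint is compound 3, whose 13.3 ug/mL stays within the scatter of compound 2 although it carries fewer hydroxy groups. The expected step of a 1.3-fold higher number from compound 2 to compound 4 (0.10 log units; within the scatter) is small, toward a slightly higher number in this assay and so slightly weaker inhibition, and it may well stay within the scatter. The estimate for compound 4 is 18 ug/mL (expected range 8 ug/mL to 42 ug/mL).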

Compound 4, half-maximal inhibitory concentration: 16.4 ug/mL
Compound 4: the middle estimate sits 1.1-fold (0.04 log units) above what was measured; measured number inside the range.
By their numbers in this assay, from the lowest: compounds 3, 2 and 4 (each within the scatter of the next); then compound 1.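

Going by these compounds alone, this is the first direct test of this change. In this assay, hydrogen in place of hydroxy on this aromatic carbon, ortho to one hydroxy group and meta to another, gives a 1.1-fold higher number from compound 2 to compound 4 (0.06 log units; within the scatter), so compound 2 and compound 4 cannot be told apart here, and inhibition in this assay does not depend measurably on this one hydroxy group. No other measurement is available that would explain this result.

The compounds shown leave open whether a methoxy group or an amine on this same carbon would also stay within the scatter of compound 2, or would move the number beyond it. Also open, going by these compounds, is whether the hydroxy groups that remain on this ring in compound 4 could be replaced by hydrogen just as easily, as one step speaks for one position only.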